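The source may report more compounds than this note shows. Statements on the series, on what has been measured and on what is new or still open speak of the compounds shown alone.

Among the measured compounds shown here, compound 1 `CN1CCN(c2ccc(NC(=N)c3cc4cn[nH]c4cn3)cc2)CC1` is the only member of this small set with a number, and in a functional assay on PC-3 cells (Homo sapiens) for cytotoxicity, read by MTT assay, with a stated time of 72 h (a higher number here means a weaker inhibitor, a lower number a stronger inhibitor), compound 1 gives 45400 nM. This value places it among weak inhibitors of these cells. Two further compounds belong to the set but carry no result: in this assay compound 2 `COc1ccc(Cn2nc(-c3ccccc3)c3cc(C(=N)Nc4cccc(C(F)(F)F)c4)nc(Nc4cc(OC)c(OC)c(OC)c4)c32)cc1` gives "not determined" (no result reported), and compound 3 `N=C(Nc1ccccc1)c1cc2cn[nH]c2cn1` gives "not determined" (no result reported), so they give no bearing on the direction that any change might take.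

The step considered here leads from compound 1 to compound 4 `COc1ccc(Cn2ncc3cc(C(=N)Nc4ccc(N5CCN(C)CC5)cc4)ncc32)cc1`. The difference is 4-methoxybenzyl in place of hydrogen on an aromatic nitrogen. For the measured compounds named here, no pair of measured compounds shows what such an addition does in this assay, so there is no measured step to lean on, and the expectation rests on the structural change alone together with the starting point of compound 1 at 45400 nM.

A moderate gain in potency, somewhat beyond the scatter, is expected, so that the step from compound 1 to compound 4 is estimated as a 3.0-fold lower number from compound 1 to compound 4 (0.48 log units; beyond the scatter). For compound 4 the expected value in this assay is 15000 nM, with a range from 3000 nM to 100000 nM.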

Compound 4, half-maximal inhibitory concentration: 6100 nM
Beside the measured number, compound 4's estimate is 2.5-fold (0.39 log units) above it; the range from low to high includes it.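

The aromatic nitrogen of the five-membered ring, which carries hydrogen in compound 1, accepts a much larger group: in this assay, 4-methoxybenzyl in place of that hydrogen gives a 7.4-fold lower number from compound 1 to compound 4 (0.87 log units; beyond the scatter). This first measured step shows that the hydrogen on this nitrogen is not required for activity against these cells, and that adding the group here strengthens the effect rather than abolishing it. Nothing available explains why the number falls.

One substituent cannot separate the contribution of the benzyl ring from that of its methoxy group, so a plain benzyl, a small methyl or a longer chain ending in an amine on the same nitrogen remains an open comparison. As far as these compounds go, it also remains open whether the same addition would lower the number with the rest of compound 1 changed.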